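The source may hold more compounds than are shown below. What is called first, only, known or untested is meant among the compounds shown, and "the series" means these compounds.

Compound 1, `c1ccc(Nc2c(-c3ccccn3)nc3ccccn23)cc1`, gives in an ADME assay on THP-1 cells (Homo sapiens) for cytotoxicity (on this read-out lower numbers stand for higher toxicity in this test and higher numbers for lower toxicity in this test), a value of 6690 nM.
Compound 2, `COc1ccccc1Nc1c(-c2ccccn2)nc2ccccn12`, reaches only a limit of this assay, > 50000 nM.
Compound 3, `Fc1ccccc1-c1nc2ccccn2c1NC1CCCC1`, likewise reaches only a limit of this assay, > 50000 nM.

Compound 1 and compound 2 differ by methoxy in place of hydrogen on an aromatic carbon. This change produced an at least 7.4-fold higher number from compound 1 to compound 2 (0.87 log units; beyond the scatter), a step that ends at a limit rather than at a number. Compound 4, `COc1ccc(-c2nc3ccccn3c2NC2CCCC2)c(F)c1`, has not yet been measured in this assay. It stands to compound 3 as compound 2 stands to compound 1: methoxy in place of hydrogen on an aromatic carbon. The surroundings are not the same word for word: in compound 2 the methoxy sits ortho to a large group, in compound 4 it sits meta to a fluoro group and para to a large group, so this is the same kind of change, not the same change. The difference between the core of compound 1 and the core of compound 3 is not broken down here. Compound 3 already sits at the limit of > 50000 nM in this assay, at which 2 of the 3 values shown sit, and on that rests the expectation of a step that the limit leaves unreadable from compound 3 to compound 4. Compound 4 is accordingly estimated at 70000 nM, most likely again reported only as a limit.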

Compound 4, half-maximal cytotoxic concentration: > 50000 nM
Compound 4 was reported as a limit; the forecaster's own chance of this, stated with the estimate: 80%; the middle value does not contradict the limit.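

In this assay compound 3 and compound 4 both end at a limit rather than at a number, so no step between them can be read: the limit of > 50000 nM in this assay, at which 3 of the 4 values shown sit.

The compounds shown leave open whether methoxy in place of hydrogen changes the read-out at all on the core of compound 3, and what number either compound would give beyond that limit.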